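This account rests on a few compounds, and the source may have more. Where it says the series, first, only, none or still open, it means among the compounds named here.

Measured compounds in an assay on THP-1 cells for displacement of a labelled ligand from C-C chemokine receptor type 1 (Homo sapiens); a higher number here means a weaker inhibitor, a lower number a stronger inhibitor:
compound 1 `CC(C)CC(=O)N[C@@H](C(=O)N1CCC(c2ccc(Cl)cc2)CC1)C(C)C`, 32 nM
compound 2 `Cc1ccc(CCC(=O)N[C@@H](C(=O)N2CCC(c3ccc(Cl)cc3)CC2)C(C)C)cc1`, 105 nM
compound 3 `CC(C)[C@@H](NC(=O)C1CCCC1)C(=O)N1CCC(c2ccc(Cl)cc2)CC1`, 70 nM

Compound 3 stands second highest of the three numbers in this assay. Its nearest neighbour is compound 2, with a 1.5-fold lower number from compound 2 to compound 3 (0.18 log units; within the scatter), a gap within the scatter; its furthest is compound 1, with a 2.2-fold higher number from compound 1 to compound 3 (0.34 log units; beyond the scatter), a gap beyond the scatter.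

Compound 4 `CC(C)[C@@H](NC(=O)Nc1ccccc1)C(=O)N1CCC(c2ccc(Cl)cc2)CC1` differs from compound 3 by anilino in place of cyclopentyl on a carbonyl carbon. Among the compounds with values here, no measured step exchanges a carbon-linked group on that carbonyl for a nitrogen-linked one, so no step bears on this change directly. The two steps that do touch this position, a 2.2-fold higher number from compound 1 to compound 3 (0.34 log units; beyond the scatter) and a 3.3-fold higher number from compound 1 to compound 2 (0.52 log units; beyond the scatter), were both modest, and the step between the two larger groups, a 1.5-fold lower number from compound 2 to compound 3 (0.18 log units; within the scatter), stayed within the scatter. Taken together, they suggest that the carbonyl substituent in this series shifts the number only moderately, whichever group is chosen. The expectation for compound 4 is therefore a change in this assay that is small, if any, with its direction uncertain.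

Compound 4 is estimated at 100 nM, with a range of 35 nM to 300 nM. This estimate corresponds to an expected 1.4-fold higher number from compound 3 to compound 4 (0.15 log units; within the scatter), a step within the scatter.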

Compound 4, half-maximal inhibitory concentration: 616 nM
For compound 4 the middle estimate is 6.2-fold (0.79 log units) below the measured one; the measured number lies above the stated range.
By their numbers in this assay, from the lowest: compound 1; then compounds 3 and 2 (each within the scatter of the next); then compound 4.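

Among compounds 1 to 3 the carbonyl substituent had moved the number only modestly, but this position proved less forgiving once a nitrogen-linked group entered, with an 8.8-fold higher number from compound 3 to compound 4 (0.94 log units; beyond the scatter) in this assay. The same holds against the other two carbon-linked groups, with a 5.9-fold higher number from compound 2 to compound 4 (0.77 log units; beyond the scatter) and a 19-fold higher number from compound 1 to compound 4 (1.28 log units; beyond the scatter), which makes compound 4 the weakest inhibitor of the four and shows that phenylcarbamoyl is not interchangeable with the acyl groups at this place. No measurement offered here explains the loss.

The change from cyclopentyl to anilino brings in a nitrogen on the carbonyl carbon, a hydrogen-bond donor and a six-membered aromatic ring all at once, so the compounds shown leave open which of these goes with the higher number. A cyclopentylamino group or a phenyl group on the same carbonyl carbon would begin to separate the nitrogen from the ring, and an N-methylanilino group would test the role of the hydrogen on that nitrogen.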